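A few compounds are considered here, and "the series" means these few. Any claim that something is new, unique, unknown or untested is made for them only; others in the source may bear on it.

Working notes on the series. The shared core is seen in compound 1 `CCc1cccc(NC(=O)CN2CCN(c3ccc(Cl)cn3)CC2)c1`, compound 2 `CCc1cccc(NC(=O)CN2CCN(c3ccccn3)CC2)c1` and compound 3 `Cc1cccc(NC(=O)CN2CCN(c3ccccn3)CC2)c1`. Compound 4 `O=C(CN1CCN(c2ccc(Cl)cn2)CC1)Nc1cccnc1` has not yet been measured.

In an assay on cells for agonist activity at D(4) dopamine receptor (Homo sapiens), read by luminescence and beta-arrestin recruitment, with a stated time of 90 min (a lower number here means a smaller maximal response, a higher number a larger maximal response), compound 1 is reported as "not active" (no number reported), with no number given. Compound 2 gives 26.2% in this assay, and compound 3 gives 30.7%. For the measured compounds named here, the only step between measured compounds, a number 4.5 percentage points higher from compound 2 to compound 3 (within the scatter), lies within the scatter and touches the group on the amide-type nitrogen while the rest of the core is kept.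

Compound 1 thus stands apart: where compound 2 and compound 3 give a number, compound 1 gives none. The change from compound 1 to compound 4 is pyridin-3-yl in place of 3-ethylphenyl on an amide-type nitrogen. Going by the values given here, no measured step covers this exchange; the step from compound 2 to compound 3 alters the same region only slightly and moves the number within the scatter, so it gives no guide for pyridin-3-yl in place of 3-ethylphenyl. Compound 4 shares with compound 1 the part of the core that sets compound 1 apart from compound 2 and compound 3, and compound 1 is not active. The expectation for compound 4 is therefore a small maximal response or again no reported number, estimated at 15%, between 0% and 35%.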

Compound 4, largest response reached (Emax), in percent of the reference or control that the assay uses: "not active" (no number reported)
Compound 4: no number reported; the estimate stays without a comparison.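

In this assay compound 1 gives "not active" (no number reported) and compound 4 gives "not active" (no number reported) so no new step can be read from this pair. The compounds shown leave open how pyridin-3-yl in place of 3-ethylphenyl on an amide-type nitrogen acts on the maximal response where a number is reported. No supporting data bear on this result.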